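Compound 2 to compound 4: a step behind limits

The source may hold more compounds than are shown below. What is called first, only, known or untested is meant among the compounds shown, and "the series" means these compounds.

In an ADME assay on BJ cells (Homo sapiens) for cytotoxicity, with a stated time of 72 h (a higher number here means that more compound is needed for the effect, a lower number that less compound is needed), compound 2 (`C=C[C@@](C)(/C=C/c1ccc(O)c(/C=C/C#N)c1)CCC=C(C)C`) reads > 36600 nM and this is a limit. Compound 1 (`C=C[C@@](C)(/C=C/c1ccc(O)c(/C=C/C(=O)c2ccccc2)c1)CCC=C(C)C`) reads > 20000 nM and this too is a limit. Compound 3 (`C=C[C@@](C)(/C=C/c1ccc(O)c(/C=C/C(=O)OCc2ccccc2)c1)CCC=C(C)C`) reads > 36600 nM and this is also a limit. Compound 4 (`C=C[C@@](C)(/C=C/c1ccc(O)c(/C=C(\C)C(=O)OCC)c1)CCC=C(C)C`) differs from compound 2 in one place (2-(ethoxycarbonyl)prop-1-en-1-yl in place of 2-cyanoethenyl on an aromatic carbon), with 2-(ethoxycarbonyl)prop-1-en-1-yl in place of 2-cyanoethenyl on an aromatic carbon. The closest measured change is a step that the two limits leave unreadable from compound 2 to compound 3 and the other two are a step that the two limits leave unreadable from compound 1 to compound 2 and a step that the two limits leave unreadable from compound 1 to compound 3 so none of them offers a size. The expected change is therefore a number no higher from compound 2 to compound 4 (the limit leaves the size open) and no shift beyond the scatter is expected in this assay in either direction. For compound 4 the estimate is 36600 nM with an expected range from 18000 nM to 73000 nM and a report of only a limit is likely.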

Compound 4, half-maximal effective concentration: > 36600 nM
Compound 4: no number, only a limit (the forecaster's own chance of this, stated with the estimate: 85%); the middle value lies on the limit itself.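

For the compounds shown here, compound 4 reads > 36600 nM in this assay, which is a limit, and compound 2 also gave only a limit, so no step between compound 2 and compound 4 can be read. The compounds shown leave open what concentration any of them needs for the effect, as all four readings are limits.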